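Swapping methylsulfanyl for trifluoromethyl in compound 2

A few compounds are considered here, and "the series" means these few. Any claim that something is new, unique, unknown or untested is made for them only; others in the source may bear on it.

In an ADME assay on MDCK cells (Canis lupus familiaris) for cytotoxicity (on this read-out lower numbers stand for higher toxicity in this test and higher numbers for lower toxicity in this test), compound 1 `O=[N+]([O-])C1=CNc2nc(-c3ccco3)nn2C1` reads 108000 nM and compound 2 `CSc1nc2n(n1)C(c1ccc(O)cc1O)C([N+](=O)[O-])=NN2` reads 201000 nM while compound 3 `CSc1nc2n(n1)C(O)C([N+](=O)[O-])=NN2` reads 99000 nM on the same scale. Compound 2 matches compound 1 within the scatter and stands just beyond the scatter above compound 3. For the measured compounds named here, compound 4 `O=[N+]([O-])C1=NNc2nc(C(F)(F)F)nn2C1c1ccc(O)cc1O` carries trifluoromethyl in place of methylsulfanyl on an aromatic carbon and no measured pair isolates that change. Compound 1 has no methylsulfanyl and still reads 108000 nM in this assay so no step beyond the scatter is expected. The expected 1.3-fold lower number from compound 2 to compound 4 (0.13 log units; within the scatter) is small and downward, inside the scatter. Compound 4 is estimated at 150000 nM with an expected range from 60000 nM to 350000 nM on this scale.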

Compound 4, half-maximal cytotoxic concentration: 108000 nM
Compound 4: middle estimate off by 1.4-fold (0.14 log units), on the high side, within the range that was stated.
By their numbers in this assay, from the lowest: compounds 3, 1, 4 and 2 (each within the scatter of the next, the first and the last beyond it).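

In this assay, for the compounds shown here, this pair is the first to isolate the position on the aromatic carbon between two ring nitrogen atoms, and it gives a 1.9-fold lower number from compound 2 to compound 4 (0.27 log units; within the scatter). For this one pair, trifluoromethyl in place of methylsulfanyl therefore produces no step beyond the scatter on the read-out. Nothing in the data shown explains this result.

Going by these compounds, it remains open whether an amine or a carboxylic acid at this position would also stay within the scatter of compound 2. On these data alone, it also remains open whether the same exchange would give a similar step on the core of compound 3.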